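The compounds below may be only part of what the source reports. "The series", "measured", "known", "first", "only" and "open" are said of these compounds alone.

Compound 2 `CCCOc1ccc(C(=O)Nc2cccc(C)n2)cc1` stands second highest of the three numbers obtained in an in vitro assay on HEK-tsA201 cells for antagonist activity at Neuronal acetylcholine receptor; alpha4/beta2 (Homo sapiens), read by fluorescence and calcium flux (a lower number here means a stronger inhibitor, a higher number a weaker inhibitor), where compound 2 gives 7500 nM. Its nearest neighbour is compound 1 `C=CCOc1ccc(C(=O)Nc2cccc(C)n2)cc1`, which gives 6000 nM; the step of a 1.3-fold higher number from compound 1 to compound 2 (0.10 log units; within the scatter) puts ethyl in place of vinyl on the chain bound to the ring oxygen. Compound 3 `CCCOc1ccc(C(=O)Nc2cnccn2)cc1` gives 23200 nM, the highest of the three. Compound 4 `CCCCCCNc1cccc(NC(=O)c2ccc(OCCC)cc2)n1` differs from compound 2 by hexylamino in place of methyl on an aromatic carbon next to the ring nitrogen. Among the compounds with values here, no measured step touches this part of the molecule, and the only measured step lay within the scatter. Compound 4 is therefore expected to give about 5000 nM, between 1000 nM and 25000 nM. The expected step is a 1.5-fold lower number from compound 2 to compound 4 (0.18 log units; within the scatter), with wide uncertainty.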

Compound 4, half-maximal inhibitory concentration: > 100000 nM
Compound 4: only a limit was reported; the forecaster's own chance of this, stated with the estimate: 15%; at least 20-fold (1.30 log units) between middle value and limit.
By their numbers in this assay, from the lowest: compounds 1 and 2 (each within the scatter of the next); then compound 3. At a limit, above all of these: compound 4.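

This position is not a neutral spot on the molecule: hexylamino in place of methyl on the aromatic carbon next to the ring nitrogen gives an at least 13-fold higher number from compound 2 to compound 4 (1.12 log units; beyond the scatter). Within the data shown here, the only earlier step, a 1.3-fold higher number from compound 1 to compound 2 (0.10 log units; within the scatter), was at the other end of the molecule, on the chain bound to the ring oxygen. Compound 4 has only a limit, not a number: the limit of > 100000 nM in this assay, at which 1 of the 4 values shown sits.

Hexylamino brings in a nitrogen and a longer chain together, and the compounds shown do not separate the two. On these data alone, whether a plain amino or a shorter methylamino group at this carbon would be tolerated remains open.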